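This account rests on a few compounds, and the source may have more. Where it says the series, first, only, none or still open, it means among the compounds named here.

Compound 1 `COc1cccc(CNCCCNc2ccnc3cc(Oc4ccc(Cl)cc4)ccc23)c1O` gives 9.28 in a physicochemical assay for acid dissociation; the two other measured numbers lie within the scatter of it. Compound 2 `c1coc(CNCCCNc2ccnc3cc(CC4CCCCC4)ccc23)c1` gives 9.47 in this assay. Compound 3 `c1coc(CNCCCNc2ccnc3cc(C4CCCCC4)ccc23)c1` gives 9.47. Among the compounds with values here, the only step through measured compounds, no change at the digits printed from compound 2 to compound 3 (within the scatter), is a swap on an aromatic carbon of the shared core and leaves the number where it was. Compound 4 `COc1ccc(-c2ccc3c(NCCCNCc4cccc(OC)c4O)ccnc3c2)cc1` differs from compound 1 by 4-methoxyphenyl in place of 4-chlorophenoxy on an aromatic carbon. Within the data shown here, no measured step touches this change directly; the one step that swaps a ring substituent shows no movement, so no step beyond the scatter is expected in this assay. For compound 4 the expected value is 9.3, within 8.9 to 9.7. The expected step is a number 0.02 log units higher from compound 1 to compound 4 (within the scatter).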

Compound 4, acid dissociation constant: 9.47
For compound 4 the middle estimate is 0.17 log units below the measured one, within the range that was stated.
By their numbers in this assay, from the lowest: compounds 1, 2, 3 and 4 (each within the scatter of the next).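

In this assay, putting 4-methoxyphenyl in place of 4-chlorophenoxy on this aromatic carbon of the shared core gives a number 0.19 log units higher from compound 1 to compound 4 (within the scatter). The earlier step covered only cyclohexyl and cyclohexylmethyl here, whereas this pair shows that two groups each carrying a six-membered aromatic ring of carbon only also stay within the scatter of each other. Nothing available gives a reason for this reading. The compounds shown leave open whether an amine or a carboxylic acid on this carbon would give a step beyond the scatter.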